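Replacing pyridin-4-yl with 4-(trifluoromethyl)phenyl on a pyrimidine ester

The source may report more compounds than this note shows. Statements on the series, on what has been measured and on what is new or still open speak of the compounds shown alone.

Measured so far in a functional assay on Jurkat cells for inhibition of nuclear factor NF-kappa-B complex (Homo sapiens); on this read-out lower numbers stand for stronger inhibition and higher numbers for weaker inhibition:
Compound 1 `CCOC(=O)c1cnc(C(C)(C)C)nc1NN1C(=O)C=C(C)C1=O`: 1000 nM
Compound 2 `CCOC(=O)c1cnc(-c2ccncc2)nc1NN1C(=O)C=C(C)C1=O`: 6000 nM
Compound 3 `CCOC(=O)c1cnc(-c2ccc(F)cc2)nc1NN1C(=O)C=C(C)C1=O`: 700 nM

Compound 2 gives the highest number of the three; its nearest neighbour is compound 1, with a 6.0-fold higher number from compound 1 to compound 2 (0.78 log units; beyond the scatter), and the furthest is compound 3, with an 8.6-fold lower number from compound 2 to compound 3 (0.93 log units; beyond the scatter). Compound 4 `CCOC(=O)c1cnc(-c2ccc(C(F)(F)F)cc2)nc1NN1C(=O)C=C(C)C1=O` is not yet measured. It differs from compound 2 in one place: 4-(trifluoromethyl)phenyl in place of pyridin-4-yl on an aromatic carbon. Within the data shown here, the step that bears on this is the one from compound 2 to compound 3, where a carbon-only six-membered ring without an acceptor also replaced pyridin-4-yl, and the step from compound 1 to compound 3 lay within the scatter. A step of comparable size downward is therefore expected, a 7.5-fold lower number from compound 2 to compound 4 (0.88 log units; beyond the scatter). Compound 4 is estimated at 800 nM, in the range 300 nM to 2500 nM.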

Compound 4, half-maximal inhibitory concentration: 400 nM
Compound 4: the middle estimate sits 2.0-fold (0.30 log units) above what was measured; the measured number falls inside the stated range.
By their numbers in this assay, from the lowest: compounds 4, 3 and 1 (each within the scatter of the next, the first and the last beyond it); then compound 2.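

In this assay, the position para to an ethoxycarbonyl group shows its widest spread so far, with a 15-fold lower number from compound 2 to compound 4 (1.18 log units; beyond the scatter) as the step. Trifluoromethyl and fluoro on the aromatic carbon cannot be told apart, with a 1.8-fold lower number from compound 3 to compound 4 (0.24 log units; within the scatter) as their step. Against tert-butyl, however, 4-(trifluoromethyl)phenyl now gives a difference beyond the scatter, with a 2.5-fold lower number from compound 1 to compound 4 (0.40 log units; beyond the scatter) as the step, which 4-fluorophenyl did not.

Nothing given here explains these steps. On these data alone, whether a 4-aminophenyl or 4-carboxyphenyl group at this position would stand with compound 4 or with compound 2 remains open.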